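From 3-bromobenzyl to 4-bromobenzyl

The source may hold more compounds than are shown below. What is called first, only, known or untested is meant among the compounds shown, and "the series" means these compounds.

In a functional assay on HeLa cells (Homo sapiens) for antiproliferative activity, read by MTT assay, with a stated time of 24 h (a lower number here means a stronger inhibitor, a higher number a weaker inhibitor), compound 1 `O=[N+]([O-])c1cccc(CSc2nnc(-c3ccc4c(c3)OCCO4)n2-c2ccccc2)c1` gives 45200 nM and compound 2 `Brc1cccc(CSc2nnc(-c3ccc4c(c3)OCCO4)n2-c2ccccc2)c1` gives 44200 nM. Among the measured compounds shown here, these two values lie within the scatter of each other, so compound 2 stands level with compound 1 on the numbers so far.

Compound 3 `Brc1ccc(CSc2nnc(-c3ccc4c(c3)OCCO4)n2-c2ccccc2)cc1` has the same atoms as compound 2, joined differently: 4-bromophenyl in place of 3-bromophenyl on a saturated chain carbon bound to a sulfur. In words, 4-bromophenyl stands in place of 3-bromophenyl on a saturated chain carbon bound to a sulfur.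

For the measured compounds named here, the only measured step is a 1.0-fold lower number from compound 1 to compound 2 (0.01 log units; within the scatter), with bromo in place of nitro on an aromatic carbon, and it lies within the scatter. Going by the values given here, no measured pair tests the present kind of change, so it only weakly informs the expectation. No shift beyond the scatter is expected in this assay, and no direction is favoured. The expected change is a 1.1-fold lower number from compound 2 to compound 3 (0.04 log units; within the scatter). For compound 3 the estimated value is 40000 nM, with an expected range of 17000 nM to 90000 nM.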

Compound 3, half-maximal inhibitory concentration: 54600 nM
For compound 3 the middle estimate is 1.4-fold (0.14 log units) below the measured one; low and high end bracket the measured number.
By their numbers in this assay, from the lowest: compounds 2, 1 and 3 (each within the scatter of the next).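

Working notes: in this assay, the shift from 3-bromobenzyl to 4-bromobenzyl gives a 1.2-fold higher number from compound 2 to compound 3 (0.09 log units; within the scatter), so this first test of where the bromo sits on the ring does not separate the two compounds. Replacing 3-nitrophenyl with 4-bromophenyl on the saturated chain carbon bound to a sulfur gives a 1.2-fold higher number from compound 1 to compound 3 (0.08 log units; within the scatter), so compounds 1, 2 and 3 all stand level in this assay, and neither change of group nor change of bromo placement has yet moved the number beyond the scatter. No supporting data are available to interpret this flat result.

Still open, from the compounds shown here alone, is whether any group at this place can move the number beyond the scatter. An amine or a carboxylic acid in place of the bromo, or a longer chain in place of the benzyl, would test this on the same core.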